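Compound 3: piperidin-1-yl for (2-methoxyphenyl)amino

The source may report more compounds than this note shows. Statements on the series, on what has been measured and on what is new or still open speak of the compounds shown alone.

In a functional assay on MGC-803 cells (Homo sapiens) for inhibition, read by sulforhodamine B assay (a lower number here means a stronger inhibitor, a higher number a weaker inhibitor), compound 2 (`COc1ccccc1NC1=CC(=O)c2c(nc3n2[C@H]2OC[C@@H](O)[C@H]2OC3)C1=O`) gives 1670 nM and lies within the scatter of compound 1 (`Cc1ccc(NC2=CC(=O)c3c(nc4n3[C@H]3OC[C@@H](O)[C@H]3OC4)C2=O)cc1`) at 1550 nM on the same core. Compound 3 (`O=C1C(N2CCCCC2)=CC(=O)c2c1nc1n2[C@H]2OC[C@@H](O)[C@H]2OC1`) carries piperidin-1-yl in place of (2-methoxyphenyl)amino on a double-bonded ring carbon. Going by the values given here, only one measured step bears on this change: a 1.1-fold higher number from compound 1 to compound 2 (0.03 log units; within the scatter) for 2-methoxyphenyl in place of 4-methylphenyl on an amine nitrogen. Both measured compounds keep a six-membered aromatic ring of carbon only, which compound 3 lacks, so this step is a weak guide. The data give no direction, and no shift beyond the scatter is expected in this assay although the uncertainty is wide. The expected step is a 1.2-fold higher number from compound 2 to compound 3 (0.08 log units; within the scatter) as a working estimate. Compound 3 is estimated at 2000 nM (expected range 600 nM to 7000 nM).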

Compound 3, half-maximal inhibitory concentration: > 4000 nM
Compound 3: only a limit was reported (the forecaster's own chance of this, stated with the estimate: 5%); middle value at least 2.0-fold (0.30 log units) away from the limit.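

Up to this point, the position on the double-bonded ring carbon had shown only a swap between (4-methylphenyl)amino and (2-methoxyphenyl)amino that stayed within the scatter; piperidin-1-yl is the first group here to shift the read-out in this assay, with an at least 2.3-fold higher number from compound 2 to compound 3 (0.37 log units; beyond the scatter) and an at least 2.5-fold higher number from compound 1 to compound 3 (0.41 log units; beyond the scatter). Compound 3 gives only a limit, > 4000 nM, so both steps fix a minimum size and not the full size of the loss: the limit of > 4000 nM in this assay, at which 1 of the 3 values shown sits. The change removes the six-membered aromatic ring of carbon only and the hydrogen-bond donor together, so these steps do not separate the two.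

Which of those two losses matters remains open, as does how far the number rises for compound 3. A cyclohexylamino group, or a methyl(phenyl)amino group, at this position would pull the two apart.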